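The source may hold more compounds than are shown below. What is called first, only, known or untested is meant among the compounds shown, and "the series" means these compounds.

The three measured compounds share one core, seen first in compound 1 `Cc1ncnc2c1ccn2[C@@H]1C=C(CO)[C@@H](O)[C@H]1O`. In an ADME assay on Huh-7 cells (Homo sapiens) for cytotoxicity (on this read-out lower numbers stand for higher toxicity in this test and higher numbers for lower toxicity in this test), compound 1 gives only a limit of the assay, > 100000 nM. Compound 2 `Cc1ncnc2c1c(Cl)cn2[C@@H]1C=C(CO)[C@@H](O)[C@H]1O` carries chloro in place of hydrogen on an aromatic carbon, and in this assay compound 2 likewise gives only a limit, > 100000 nM. Compound 3 `Cc1ncnc2c1c(I)cn2[C@@H]1C=C(CO)[C@@H](O)[C@H]1O` carries iodo in place of hydrogen on that aromatic carbon, and in this assay compound 3 again gives only a limit, > 100000 nM. Compound 3 therefore stands exactly where the other two stand, at the limit of > 100000 nM in this assay, at which 3 of the 3 values shown sit. The steps a step that the two limits leave unreadable from compound 1 to compound 2, a step that the two limits leave unreadable from compound 1 to compound 3 and a step that the two limits leave unreadable from compound 2 to compound 3 cannot be sized because every value involved sits at the limit of > 100000 nM in this assay, at which 3 of the 3 values shown sit.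

Compound 4 `C=Cc1cn([C@@H]2C=C(CO)[C@@H](O)[C@H]2O)c2ncnc(C)c12` differs from compound 3 by vinyl in place of iodo on an aromatic carbon. All three measured steps bear on this change as substitutions at the same aromatic carbon, yet none yields a readable size, so no step beyond the scatter in this assay from compound 3 to compound 4 is expected. Compound 4 is thus estimated at 150000 nM in this assay, within 50000 nM to 500000 nM, most probably reported once more only as a limit. The expected step is a step that the limit leaves unreadable from compound 3 to compound 4.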

Compound 4, half-maximal cytotoxic concentration: 52800 nM
Compound 4: the middle estimate sits 2.8-fold (0.45 log units) above what was measured, within the range that was stated.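

In this assay, for the compounds shown here, vinyl is the first group at this aromatic carbon to give a measured number rather than a limit, which hydrogen, chloro and iodo at the same carbon did not do: the limit of > 100000 nM in this assay, at which 3 of the 4 values shown sit. The change to vinyl can now be stated as an at least 1.8-fold lower number from compound 3 to compound 4 (0.27 log units; that floor lies within the scatter), as an at least 1.8-fold lower number from compound 2 to compound 4 (0.27 log units; that floor lies within the scatter) and as an at least 1.8-fold lower number from compound 1 to compound 4 (0.27 log units; that floor lies within the scatter). Each of these steps is a floor, and since each floor lies within the scatter, the result does not firmly set compound 4 apart from the other three, although it does show that this position can carry a group with a double bond outside aromatic rings and still give a readable number.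

On these data alone, the true distance between compound 4 and compounds 1, 2 and 3 stays open, as their values are limits only. As far as these compounds go, it also remains open whether the double bond of vinyl matters at this position, which ethyl would test, and whether a longer chain such as propyl or an ethynyl group would bring the number down further.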